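Replacing tert-butyl with 2-cyanophenyl: cytotoxicity outlook

A few compounds are considered here, and "the series" means these few. Any claim that something is new, unique, unknown or untested is made for them only; others in the source may bear on it.

Among the compounds with values here, compound 2 `Cc1c(Cc2ccc(C(C)(C)C)cc2)c(=O)oc2cc(OCC(O)CN3CCC(C(N)=O)CC3)ccc12` is the only member of this set with a numerical reading in an ADME assay on A549 cells (Homo sapiens) for cytotoxicity, read by CellTiter-Glo; a lower number here means that less compound is tolerated, a higher number that more compound is tolerated: compound 2 gives 14700 nM. Compound 1 `Cc1c(Cc2ccccc2)c(=O)oc2cc(OCC(O)CNCc3ccccc3)ccc12` sits at the assay limit, returning in this assay a value of > 100000 nM. Compound 3 `Cc1c(Cc2ccccc2C(F)(F)F)c(=O)oc2cc(OCC(O)CN3CCC(C(N)=O)CC3)ccc12` likewise returns only the limit in this assay, namely > 100000 nM. Within the data shown here, two of the three readings are therefore limits, and compound 2 stands as the single compound with a measurable number (the limit of > 100000 nM in this assay, at which 2 of the 3 values shown sit).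

Compound 4 `Cc1c(Cc2ccc(-c3ccccc3C#N)cc2)c(=O)oc2cc(OCC(O)CN3CCC(C(N)=O)CC3)ccc12` differs from compound 2 by 2-cyanophenyl in place of tert-butyl on an aromatic carbon. Among the measured compounds shown here, the one measured step touching the same region is an at least 6.8-fold higher number from compound 2 to compound 3 (0.83 log units; beyond the scatter), in which the 4-(tert-butyl)phenyl was exchanged for 2-(trifluoromethyl)phenyl and the reading moved at least modestly upward, as far as the limit. Compound 4 alters only the tert-butyl of compound 2, so a shift smaller than that step is plausible, yet the expected direction in this assay is upward. For compound 4 a step of a 3.1-fold higher number from compound 2 to compound 4 (0.49 log units; beyond the scatter) is expected. Compound 4 is accordingly estimated at 45000 nM, within the range 15000 nM to 130000 nM, with a fair chance that only the limit is reported.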

Compound 4, half-maximal cytotoxic concentration: 33200 nM
The estimate for compound 4 lay 1.4-fold (0.13 log units) above the measured number, and the stated range covers the measured number.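

In this assay, 2-cyanophenyl in place of tert-butyl gives a 2.3-fold higher number from compound 2 to compound 4 (0.35 log units; beyond the scatter), so a change on this aromatic carbon alone moves the reading, and the larger group does not lower the number. Within the data shown here, this is the first step with a number at both ends, whereas the earlier step from compound 2 ended at a limit and its full size could not be read. Compound 4 gives a number rather than a limit, which leaves room to read further changes at this place against the ceiling of the assay: the limit of > 100000 nM in this assay, at which 2 of the 4 values shown sit.

Compound 4 brings in the aromatic ring and the nitrile together, so the step cannot be assigned to either one. A plain phenyl, or a carboxylic acid or an amine in place of the nitrile, would separate the two.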